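Replacing the dihydroxyphenyl of compound 3 with a hydroxynaphthyl

This account rests on a few compounds, and the source may have more. Where it says the series, first, only, none or still open, it means among the compounds named here.

Compound 1, `COc1ccc(OC)c(/C=N/NC(=O)Nc2ccc(Oc3ccnc(-c4nncn4CCN(C)C)c3)c(F)c2)c1`, in a functional assay on A549 cells (Homo sapiens) for cytotoxicity, read by MTT assay, with a stated time of 72 h; a lower number here means a stronger inhibitor, a higher number a weaker inhibitor: 1950 nM.
Compound 2, `CN(C)CCn1cnnc1-c1cc(Oc2ccc(NC(=O)N/N=C/c3ccccc3O[N+](=O)[O-])cc2F)ccn1`, gives 1200 nM.
Compound 3, `CN(C)CCn1cnnc1-c1cc(Oc2ccc(NC(=O)N/N=C/c3ccc(O)c(O)c3)cc2F)ccn1`, reaches only the limit of the assay, > 100000 nM.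

Within the data shown here, compound 3 thus stands at the upper edge of what this assay reports; its value is a limit, not a number, and it is the one value sitting there (the limit of > 100000 nM in this assay, at which 1 of the 3 values shown sits). Compound 4, `CN(C)CCn1cnnc1-c1cc(Oc2ccc(NC(=O)N/N=C/c3c(O)ccc4ccccc34)cc2F)ccn1`, differs from it in one place: 2-hydroxynaphthalen-1-yl in place of 3,4-dihydroxyphenyl on a carbon with a double bond to nitrogen. The measured steps that reach compound 3 are an at least 51-fold higher number from compound 1 to compound 3 (1.70 log units; beyond the scatter) and an at least 83-fold higher number from compound 2 to compound 3 (1.92 log units; beyond the scatter), both large and both in the direction of a weaker inhibitor once the 3,4-dihydroxyphenyl enters. Removing that group again is therefore expected to run the other way, with a large decrease in number, an at least 33-fold lower number from compound 3 to compound 4 (1.52 log units; beyond the scatter). Compound 4 is estimated to give about 3000 nM, within a range from 800 nM to 20000 nM.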

Compound 4, half-maximal inhibitory concentration: 880 nM
Compound 4: middle estimate off by 3.4-fold (0.53 log units), on the high side; measured number inside the range.
By their numbers in this assay, from the lowest: compounds 4, 2 and 1 (each within the scatter of the next, the first and the last beyond it). At a limit, above all of these: compound 3.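

A hydroxyl-bearing group at this place need not leave the compound at the edge of the assay: 2-hydroxynaphthalen-1-yl in place of 3,4-dihydroxyphenyl gives an at least 110-fold lower number from compound 3 to compound 4 (2.05 log units; beyond the scatter). That step starts from a limit, not a number: the limit of > 100000 nM in this assay, at which 1 of the 4 values shown sits. The other two steps are a 1.4-fold lower number from compound 2 to compound 4 (0.13 log units; within the scatter), within the scatter, and a 2.2-fold lower number from compound 1 to compound 4 (0.35 log units; beyond the scatter), a modest step beyond it.

Among these compounds, what remains open is whether the second ring of the naphthalene or the single hydroxyl separates compound 4 from compound 3. A plain 2-hydroxyphenyl or an amine at this place would bear on that question.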